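Anilinoquinazoline analogues: predicting the fluoro variant

The source may hold more compounds than are shown below. What is called first, only, known or untested is meant among the compounds shown, and "the series" means these compounds.

Measured compounds, a functional assay on A-431 cells (Homo sapiens) for antiproliferative activity, read by MTT assay, with a stated time of 72 h; on this read-out higher numbers stand for weaker inhibition and lower numbers for stronger inhibition:
- compound 1, `C#Cc1cccc(Nc2ncnc3cc(OC)c(OCCCN4CCNCCNCCNCC4)cc23)c1`, gives 1110 nM
- compound 2, `COc1cc2ncnc(Nc3ccc(F)c(Br)c3)c2cc1OCCCN1CCNCCNCCNCC1`, gives 1580 nM
- compound 3, `COc1cccc(Nc2ncnc3cc(OC)c(OCCCN4CCNCCNCCNCC4)cc23)c1`, gives 3210 nM

Compound 1 has the lowest number of the three. Its gap to compound 2 is a 1.4-fold higher number from compound 1 to compound 2 (0.15 log units; within the scatter), within the scatter, while its gap to compound 3 is a 2.9-fold higher number from compound 1 to compound 3 (0.46 log units; beyond the scatter), a modest loss that goes beyond the scatter. For the measured compounds named here, the single change from compound 1 to compound 4, `COc1cc2ncnc(Nc3cccc(F)c3)c2cc1OCCCN1CCNCCNCCNCC1`, is fluoro in place of ethynyl on an aromatic carbon.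

Going by the values given here, two measured steps bear on this. Replacing ethynyl by methoxy on the same aromatic carbon cost a 2.9-fold higher number from compound 1 to compound 3 (0.46 log units; beyond the scatter), and swapping 3-bromo-4-fluorophenyl for 3-methoxyphenyl cost a 2.0-fold higher number from compound 2 to compound 3 (0.31 log units; beyond the scatter). Both show that a smaller or different group at this position tends to weaken inhibition, but the bromo-fluoro aryl of compound 2 stayed within the scatter of compound 1. Among the compounds with values here, no measured step tells directly what fluoro alone does. The expectation for compound 4 is therefore a modest rise in this assay number, a 2.0-fold higher number from compound 1 to compound 4 (0.30 log units; within the scatter), between the flat step to compound 2 and the loss seen for compound 3.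

Compound 4 is expected at 2200 nM, with a range from 1100 nM to 4500 nM.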

Compound 4, half-maximal inhibitory concentration: 1860 nM
Compound 4: middle estimate off by 1.2-fold (0.07 log units), on the high side; measured number inside the range.
By their numbers in this assay, from the lowest: compounds 1, 2, 4 and 3 (each within the scatter of the next, the first and the last beyond it).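

Fluoro on this aromatic carbon stays within the scatter of both ethynyl a 1.7-fold higher number from compound 1 to compound 4 (0.22 log units; within the scatter) and methoxy a 1.7-fold lower number from compound 3 to compound 4 (0.24 log units; within the scatter), although ethynyl and methoxy themselves lie beyond the scatter of each other a 2.9-fold higher number from compound 1 to compound 3 (0.46 log units; beyond the scatter). In this assay, the triple bond that leaves with ethynyl is therefore not shown to be needed, and removing the bromo from the 3-bromo-4-fluorophenyl group while moving to 3-fluorophenyl also stays within the scatter a 1.2-fold higher number from compound 2 to compound 4 (0.07 log units; within the scatter). No measured information explains the size of these steps.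

With these steps inside the scatter, fluoro cannot be ranked against ethynyl, methoxy or the 3-bromo-4-fluorophenyl group. Going by these compounds, it remains open what an amine, a carboxylic acid or a nitrile on this aromatic carbon would give, and whether any of them would separate from compound 1 beyond the scatter.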